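The compounds below may be only part of what the source reports. "The series", "measured", "known", "first", "only" and "open" are said of these compounds alone.

In a functional assay on CHO-K1 cells for antagonist activity at adenosine receptor A2b (Homo sapiens), read by FLIPR and calcium flux (a lower number here means a stronger inhibitor, a higher number a weaker inhibitor), three compounds have been measured:

compound 1 `O=C(c1ccccc1)c1nc(NCc2cccnc2)nc2ccsc12` gives 511 nM
compound 2 `Cc1ccc(C(=O)c2nc(NCc3cccnc3)nc3ccsc23)cc1` gives 215 nM
compound 3 `O=C(c1cccnc1)c1nc(NCc2cccnc2)nc2ccsc12` gives 109 nM

Compound 3 stands at the low end of these numbers. One step, a 4.7-fold lower number from compound 1 to compound 3 (0.67 log units; beyond the scatter), lies beyond the scatter, while the other, a 2.0-fold lower number from compound 2 to compound 3 (0.30 log units; within the scatter), lies within the scatter, so compound 2 and compound 3 cannot be told apart. The methyl step, a 2.4-fold lower number from compound 1 to compound 2 (0.38 log units; beyond the scatter), is the other change seen so far.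

Compound 4 `CC(C)NC(=O)c1nc(NCc2cccnc2)nc2ccsc12` differs from compound 3 by isopropylamino in place of pyridin-3-yl on a carbonyl carbon. Among the compounds with values here, both earlier steps at the carbonyl carbon, a 4.7-fold lower number from compound 1 to compound 3 (0.67 log units; beyond the scatter) and a 2.0-fold lower number from compound 2 to compound 3 (0.30 log units; within the scatter), exchanged one aromatic ring for another; neither replaced the ring with an amino group, and no measured pair shows an amide in this position. The earlier steps shown here therefore bear on this change only loosely, and they say nothing about its direction.

Within the data shown here, with no direct precedent, compound 4 is expected to give a somewhat higher number than compound 3, a step of a 3.7-fold higher number from compound 3 to compound 4 (0.56 log units; beyond the scatter), with wide uncertainty. The estimate for compound 4 in this assay is 400 nM, within a range from 100 nM to 1600 nM.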

Compound 4, half-maximal inhibitory concentration: 309 nM
Estimate against measurement, compound 4: 1.3-fold (0.11 log units) above; low and high end bracket the measured number.
By their numbers in this assay, from the lowest: compounds 3, 2, 4 and 1 (each within the scatter of the next, the first and the last beyond it).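

In this assay, within the data shown here, this is the first amide at the carbonyl carbon, and a 2.8-fold higher number from compound 3 to compound 4 (0.45 log units; beyond the scatter) shows that isopropylamino, which has no ring, does not match pyridin-3-yl there. The comparisons with the other two ketones read differently: a 1.4-fold higher number from compound 2 to compound 4 (0.16 log units; within the scatter) and a 1.7-fold lower number from compound 1 to compound 4 (0.22 log units; within the scatter) both stay within the scatter, so isopropylamino cannot be told apart from 4-methylphenyl or phenyl at this position, and an aromatic ring on the carbonyl carbon is not needed for a number in this range among these compounds. Nothing measured here accounts for the gap between pyridin-3-yl and isopropylamino.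

The compounds shown leave open whether the amide hydrogen matters, which a dimethylamino group on the same carbonyl carbon would test, and whether the size of the amine matters, which cyclopropylamino or tert-butylamino would address. They also leave open whether a pyridin-3-ylamino group, which would combine the amide with the ring of compound 3, would give a lower number than either parent group does.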